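Swapping methoxy for methyl in a growth inhibition series

The source may report more compounds than this note shows. Statements on the series, on what has been measured and on what is new or still open speak of the compounds shown alone.

Compound 1 `COc1ccc(SCc2ccc(/C=C/C(=O)Nc3ccccc3N)cc2)cc1OC` gives 46%
Compound 2 `COc1ccc(SCc2ccc(C(=O)Nc3ccccc3N)cc2)cc1` gives 10.2%

Both numbers come from a functional assay on A-375 cells (Homo sapiens) for inhibition, read by CCK-8 assay, with a stated time of 72 h, tested at 2 uM (a lower number here means less inhibition of growth, a higher number more inhibition of growth at the concentration tested), and compound 2 is the lower of the two, with compound 1 standing above it beyond the usual scatter. Compound 3 `Cc1ccc(SCc2ccc(C(=O)Nc3ccccc3N)cc2)cc1` has not yet been measured. It departs from compound 2 by methyl in place of methoxy on an aromatic carbon, para to a large group, and the count of that change is methyl in place of methoxy on an aromatic carbon in full. For the measured compounds named here, no two measured compounds differ in one place only, so nothing here sizes such a swap directly. A small step in this assay is expected, most likely within the scatter and with no firm direction. The estimated change is a number 1.8 percentage points higher from compound 2 to compound 3 (within the scatter) as a rough expectation. For compound 3 the expected value is 12% within an estimated range from 2% to 25% in this read-out.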

Compound 3, percent growth inhibition at one concentration: 17.5%
The estimate for compound 3 lay 5.5 percentage points below the measured number; low and high end bracket the measured number.
By their numbers in this assay, from the lowest: compounds 2 and 3 (each within the scatter of the next); then compound 1.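

For the compounds shown here, this is the first direct reading of a swap at this position: in this assay, the change from methoxy to methyl on an aromatic carbon, para to a large group, comes to a number 7.3 percentage points higher from compound 2 to compound 3 (within the scatter). With 4-methoxyphenyl replaced by 4-methylphenyl, the loss of the one hydrogen-bond acceptor counted for methoxy leaves the two compounds inseparable at the concentration tested, so this pair of groups does not distinguish them in this read-out. No measurement available here bears on why the two groups read alike.

From the compounds shown here alone, whether an amine, a carboxylic acid or a longer chain on the same aromatic carbon would move the number beyond the scatter remains open. Going by these compounds, it is also open whether the same swap would read alike on the core of compound 1.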